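A few compounds are considered here, and "the series" means these few. Any claim that something is new, unique, unknown or untested is made for them only; others in the source may bear on it.

Working notes on the series. Compound 1 `CCn1c(=O)c2[nH]c(-c3cccs3)nc2n(CCCOC)c1=O` and compound 2 `CCCn1c(=O)c2[nH]c(-c3ccccc3)nc2n(CCCOC)c1=O` share one core and differ at more than one place, so no single step can be read from them. In an assay on HEK293 cells for binding affinity to adenosine receptor A2b (Homo sapiens) (on this read-out higher numbers stand for weaker inhibition and lower numbers for stronger inhibition), compound 1 gives 126 nM. In this assay, for the measured compounds named here, compound 2 gives 324 nM, the higher of the two numbers so far; the gap to compound 1 lies beyond the scatter.

Compound 3 `CCCn1c(=O)c2[nH]c(-c3ccc[nH]3)nc2n(CCCOC)c1=O` is the next step from compound 2: 1H-pyrrol-2-yl in place of phenyl on an aromatic carbon, on an aromatic carbon of a five-membered aromatic ring with two nitrogen, part of a fused system of two rings, between two ring nitrogen atoms. Going by the values given here, with no step of this kind measured, the expectation rests only on compound 1, whose five-membered ring at the same place gives 126 nM. Compound 3 is therefore expected to move toward a lower number, by about a 2.0-fold lower number from compound 2 to compound 3 (0.31 log units; beyond the scatter). For compound 3 the estimate in this assay is 160 nM, with a range from 50 nM to 500 nM.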

Compound 3, inhibition constant: 148 nM
The estimate for compound 3 lay 1.1-fold (0.03 log units) above the measured number; the range from low to high includes it.
By their numbers in this assay, from the lowest: compounds 1 and 3 (each within the scatter of the next); then compound 2.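

At the aromatic carbon between two ring nitrogen atoms, the series now has its first change at a single place: in this assay the step of a 2.2-fold lower number from compound 2 to compound 3 (0.34 log units; beyond the scatter) comes with 1H-pyrrol-2-yl in place of phenyl. This shows that the group at this position can shift the number with the rest of the molecule held fixed. The change replaces a six-membered aromatic ring of carbon only with a five-membered aromatic ring with 1 hetero atom and adds 1 hydrogen-bond donor, and this one step cannot separate those differences. No measurement available here accounts for the step.

Compounds 1 and 3 differ at more than one place, so no step can be read between them. Open, from the compounds shown here alone, is whether 1-methylpyrrol-2-yl or furan-2-yl at this carbon would give a number like that of compound 3.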